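The compounds below may be only part of what the source reports. "The series", "measured", "known", "first", "only" and "open" are said of these compounds alone.

Three compounds have been measured so far in a functional assay on HL-60 cells (Homo sapiens) for inhibition, read by MTT assay, with a stated time of 72 h; on this read-out higher numbers stand for weaker inhibition and lower numbers for stronger inhibition:

compound 1 `Cc1nc(-c2ccccc2)c(C(=O)N2CCN(c3cccc(Cl)c3)CC2)o1` gives 39.2 nM
compound 2 `COc1cccc(N2CCN(C(=O)c3oc(C)nc3-c3ccccc3)CC2)c1` gives 34.8 nM
compound 3 `Cc1nc(-c2ccccc2)c(C(=O)N2CCN(c3cccc(F)c3)CC2)o1` gives 45 nM

Within the data shown here, these three share a core and differ only in the single group that is chloro, methoxy or fluoro. Compound 2 (34.8 nM) cannot be separated from the other two, since the steps that link it to them are a 1.1-fold lower number from compound 1 to compound 2 (0.05 log units; within the scatter) and a 1.3-fold higher number from compound 2 to compound 3 (0.11 log units; within the scatter). The remaining step is a 1.1-fold higher number from compound 1 to compound 3 (0.06 log units; within the scatter), so all three are level within the scatter.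

The next compound is compound 4 `COc1cccc(N2CCN(C(=O)c3oc(C)nc3-c3cccc(F)c3)CC2)c1`, which is compound 2 with one change: fluoro in place of hydrogen on an aromatic carbon. This is fluoro in place of hydrogen on an aromatic carbon, meta to a large group, and it can also be read as phenyl to 3-fluorophenyl.

Among the measured compounds shown here, no measured pair carries a change at this place, so the evidence is indirect. The closest guides are the two steps above that bring in fluoro elsewhere, a 1.1-fold higher number from compound 1 to compound 3 (0.06 log units; within the scatter) and a 1.3-fold higher number from compound 2 to compound 3 (0.11 log units; within the scatter), and neither goes beyond the scatter. No step beyond the scatter, in either direction, is therefore expected in this assay, though the range must stay wide. The estimated step is a 1.0-fold higher number from compound 2 to compound 4 (0.00 log units; within the scatter). Compound 4 is expected at 35 nM (estimated range 14 nM to 90 nM).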

Compound 4, half-maximal inhibitory concentration: "not active" (no number reported)
Compound 4: no number reported; the estimate stays without a comparison.
By their numbers in this assay, from the lowest: compounds 2, 1 and 3 (each within the scatter of the next).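

In this assay, among these compounds, compound 4 is reported only as "not active", without a number, so no step from compound 2 to compound 4 can be read. The compounds shown leave open how phenyl to 3-fluorophenyl changes the number on any other compound in this series. No other data here bear on this result.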